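The source may report more compounds than this note shows. Statements on the series, on what has been measured and on what is new or still open speak of the compounds shown alone.

The measured compounds:

Compound 1, `Cc1nn(CC2(O)COC2)cc1Nc1nc(N)c2c(C#N)c(N3CCC[C@H]3C)n(C)c2n1`, gives 250 nM in an assay on HEK293 cells for inhibition of Leucine-rich repeat serine/threonine-protein kinase 2 variant G2019S (Homo sapiens), with a stated time of 48 h; a higher number here means a weaker inhibitor, a lower number a stronger inhibitor.
Compound 2, `Cc1c(Nc2nc(N)c3c(C#N)c(N4CCC[C@H]4C)n(C)c3n2)cnn1CC(C)(C)O`, gives 120 nM in this assay.
Compound 3, `Cc1nn(C)cc1Nc1nc(N)c2c(C#N)c(N3CCC[C@H]3C)n(C)c2n1`, gives 120 nM in this assay.

Compound 3 stands level with compound 2 at the digits shown, and these two share the lowest numbers of the three. Among the compounds with values here, the only single-point step among the measured compounds is a 2.1-fold lower number from compound 1 to compound 3 (0.32 log units; beyond the scatter), a modest change that lies just beyond the usual scatter.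

Compound 4, `C[C@@H]1CCCN1c1c(C#N)c2c(N)nc(Nc3cn(C)nc3C(F)(F)F)nc2n1C`, has not yet been measured. It differs from compound 3 in one place: trifluoromethyl in place of methyl on an aromatic carbon. Within the data shown here, the measured step concerns a group on a saturated chain carbon bound to an aromatic nitrogen, a different place from the aromatic carbon altered here, so no measured step bears directly on this change. With the three measured values sitting close together, the expectation for the step of a 1.3-fold higher number from compound 3 to compound 4 (0.10 log units; within the scatter) is a change no larger than the scatter, in either direction. Compound 4 is therefore estimated at 150 nM in this assay, with a range from 50 nM to 500 nM.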

Compound 4, half-maximal inhibitory concentration: 460 nM
Beside the measured number, compound 4's estimate is 3.1-fold (0.49 log units) below it, and the stated range covers the measured number.
By their numbers in this assay, from the lowest: compounds 2 and 3 (each within the scatter of the next); then compounds 1 and 4 (each within the scatter of the next).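

In this assay, replacing methyl with trifluoromethyl on this aromatic carbon gives a 3.8-fold higher number from compound 3 to compound 4 (0.58 log units; beyond the scatter), a modest step but one beyond the scatter. Compound 1 and compound 3 both carry methyl on this carbon, so the earlier step could say nothing about this position; the new step shows that the number responds to a change here. Nothing available explains why the number rises with this swap.

From the compounds shown here alone, with only methyl and trifluoromethyl compared, it remains open how this carbon would respond to other groups, such as an ethyl chain, a chlorine atom, a methoxy group or an amine. Going by these compounds, it is also open whether the same swap would give a similar step on compound 1, which has a different group on the ring nitrogen.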